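The source may report more compounds than this note shows. Statements on the series, on what has been measured and on what is new or still open speak of the compounds shown alone.

Of the compounds shown here, three have so far been measured in an assay on isolated protein for inhibition of Maltase-glucoamylase (Homo sapiens), with stated times of 15 min and 10 min, tested at 64 uM; a higher number here means more inhibition at the concentration tested (going by the name of the read-out), a lower number less inhibition. Compound 1 `C=CCc1ccc(O)c(-c2cc(CC=C)cc(CN(CCCC)CCCC)c2O)c1` gives 8.2%, and compound 2 `C=CCc1cc(CN(CCC)CCC)c(O)c(-c2cc(CC=C)c(O)c(CN(CCC)CCC)c2)c1` gives 4.8%. Compound 3 `C=CCc1cc(-c2ccc(O)c(CC=C)c2)c(O)c(C(c2cc(OC)c(OC)c(OC)c2)N2CCCC2)c1` stands highest of the three numbers with 43%; its nearest neighbour, compound 1, lies lower by a margin beyond the scatter, and compound 2 lies lower still, also beyond the scatter. Compound 4 `C=CCc1cc(-c2ccc(O)c(CC=C)c2)c(O)c(C(c2cc(OC)c(OC)c(OC)c2)N2CCCCC2)c1` is not yet measured. It differs from compound 3 in one place: piperidin-1-yl in place of pyrrolidin-1-yl on a saturated chain carbon bound to two aromatic carbons. Among the measured compounds shown here, no pair of measured compounds shows this change, so there is nothing to set its size from directly. A step from compound 3 to compound 4 of a number 3 percentage points lower from compound 3 to compound 4 (within the scatter) is expected, not beyond the scatter in either direction. Compound 4 is estimated at 40%, within 20% to 60%, in this assay.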

Compound 4, a percentage reported as inhibition, at one concentration (the size of the read-out at that concentration, not a potency): 56.4%
For compound 4 the middle estimate is 16.4 percentage points below the measured one, within the range that was stated.
By their numbers in this assay, from the lowest: compounds 2 and 1 (each within the scatter of the next); then compound 3; then compound 4.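

In this assay, among the compounds shown here, the ring on the saturated chain carbon bound to two aromatic carbons proves to matter: piperidin-1-yl in place of pyrrolidin-1-yl gives a number 13.4 percentage points higher from compound 3 to compound 4 (beyond the scatter) and this is the first step that can be read at this position. The earlier compounds shown here offered no pair differing in one place, so the effect of this ring swap could not be sized before. No evidence at hand bears on why the number rises.

From the compounds shown here alone, whether azepan-1-yl or morpholin-4-yl at this position would raise the number further remains open. So does whether the gain from piperidin-1-yl would hold with a different group in place of the 3,4,5-trimethoxyphenyl group on the same carbon.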